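The source may hold more compounds than are shown below. What is called first, only, known or untested is meant among the compounds shown, and "the series" means these compounds.

Measured so far in a functional assay on CHO cells for agonist activity at Free fatty acid receptor 2 (Homo sapiens), read by cAMP accumulation; on this read-out lower numbers stand for smaller maximal responses and higher numbers for larger maximal responses:
Compound 1, `CC(C)[C@H](C(=O)NC(C)(C)C)c1ccc(Cl)cc1`: < 30%
Compound 2, `CC(C)[C@H](C(=O)Nc1nnc(C(F)(F)F)s1)c1ccc(Cl)cc1`: 115%
Compound 3, `CC(C)(C)[C@H](C(=O)Nc1ncc(Br)s1)c1ccc(Cl)cc1`: 95%

The value of compound 1 is a limit of the assay rather than a number (the limit of < 30% in this assay, at which 1 of the 3 values shown sits). Of the two numbers, compound 3 stands lowest, and the value of compound 2 sits above it by more than the usual scatter.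

Compound 4, `CN(C)c1cnc(NC(=O)[C@H](c2ccc(Cl)cc2)C(C)(C)C)s1`, has not been measured. It differs from compound 3 in one place: dimethylamino in place of bromo on an aromatic carbon. Within the data shown here, no measured pair shows this change, so nothing tells how large the step in this assay will be. A step within the scatter, in no clear direction, is expected. The expected step is no change at the digits printed from compound 3 to compound 4 (within the scatter). Compound 4 is estimated at 95%, with a range from 70% to 115%.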

Compound 4, largest response reached (reported as efficacy), in percent of the reference or control that the assay uses: 112%
For compound 4 the middle estimate is 17 percentage points below the measured one, and the stated range covers the measured number.
By their numbers in this assay, from the lowest: compound 3; then compounds 4 and 2 (each within the scatter of the next). At a limit, below all of these: compound 1.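

Replacing bromo with dimethylamino on the aromatic carbon next to the ring sulfur gives, in this assay, a number 17 percentage points higher from compound 3 to compound 4 (beyond the scatter). Among these compounds, this is the first readable step at this position, and it shows that the position accepts a group with more heavy atoms and a hydrogen-bond acceptor without any loss of maximal response. Nothing in the data shown explains the rise.

A single change cannot show whether the step follows the nitrogen or the added carbons. Going by these compounds, whether a primary amine, a longer chain or a carboxylic acid on this carbon would give a similar response remains open.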